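One Extra Methyl on a Weakly Active Ester

This account rests on a few compounds, and the source may have more. Where it says the series, first, only, none or still open, it means among the compounds named here.

The starting point is compound 1 `CCCC(O)CC(=O)O[C@H](CC=C(C)C)C1=CC(=O)c2c(O)ccc(O)c2C1=O`. In a functional assay on DU-145 cells (Homo sapiens) for cytotoxicity, read by MTT assay (a higher number here means a weaker inhibitor, a lower number a stronger inhibitor), compound 1 gives > 100000 nM, which is a limit of the assay rather than a measured number, so only a bound is known for it; this is the limit of > 100000 nM in this assay, at which 1 of the 3 values shown sits. Two related compounds were measured in this assay. Compound 2 `COCCO[C@H](CC=C(C)C)C1=CC(=O)c2c(O)ccc(O)c2C1=O` gives 43200 nM in this assay, and the step of an at least 2.3-fold lower number from compound 1 to compound 2 (0.36 log units; beyond the scatter) counts as at least modest. Compound 3 `CCCCC(CC(=O)O[C@H](CC=C(C)C)C1=CC(=O)c2c(O)ccc(O)c2C1=O)OC(C)=O` gives 67700 nM in this assay, and the step of an at least 1.4-fold lower number from compound 1 to compound 3 (0.16 log units; that floor lies within the scatter) has a floor that stays within the scatter.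

Compound 4 `CCCC(C)(O)CC(=O)O[C@H](CC=C(C)C)C1=CC(=O)c2c(O)ccc(O)c2C1=O` differs from compound 1 by methyl in place of hydrogen on a saturated chain carbon bound to an oxygen on a saturated carbon and two saturated chain carbons. Within the data shown here, no measured step makes exactly this change. Both measured steps alter the ester side of compound 1 and leave the number at or modestly below its limit, so a small step, in either direction or none beyond the scatter, is expected in this assay. Compound 4 is estimated at 100000 nM, with a range from 40000 nM to 300000 nM, which means an expected a number no higher from compound 1 to compound 4 (the limit leaves the size open).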

Compound 4, half-maximal inhibitory concentration: 75000 nM
Compound 4: middle estimate off by 1.3-fold (0.12 log units), on the high side; low and high end bracket the measured number.
By their numbers in this assay, from the lowest: compounds 2, 3 and 4 (each within the scatter of the next). At a limit, above all of these: compound 1.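

On the 1-hydroxybutyl chain, methyl in place of hydrogen gives a number that can be read in this assay, with an at least 1.3-fold lower number from compound 1 to compound 4 (0.12 log units; that floor lies within the scatter). The new chain also cannot be told apart from two quite different ester-side groups, with a 1.1-fold higher number from compound 3 to compound 4 (0.04 log units; within the scatter) and with a 1.7-fold higher number from compound 2 to compound 4 (0.24 log units; within the scatter), so none of the three side chains shown stands out. The real size of the methyl step stays unknown because compound 1 sits at a limit: the limit of > 100000 nM in this assay, at which 1 of the 4 values shown sits.

The compounds shown leave open whether ethyl on this same carbon would change the number any further than methyl does. They also do not tell what an amine in place of the hydroxyl on this carbon would do.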